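The compounds below may be only part of what the source reports. "The series", "measured", "known", "first", "only" and "open" are said of these compounds alone.

Series notes. Compound 1 `CC(C)(C)c1ccc(CN2C(=O)S/C(=C\c3cccc(N)c3)C2=O)cc1` gives 145000 nM in a functional assay on HeLa cells (Homo sapiens) for cytotoxicity, read by cell counting, with a stated time of 4 days; on this read-out lower numbers stand for stronger inhibition and higher numbers for weaker inhibition. Compound 2 `Nc1cccc(/C=C2\SC(=O)N(Cc3ccc(C(F)(F)F)cc3)C2=O)c1` returns only a limit of this assay, > 250000 nM. Compound 3 `Cc1ccc(CN2C(=O)S/C(=C\c3ccc(N)cc3)C2=O)cc1` likewise returns only a limit, > 250000 nM, so it sits at the floor of the numbers shown, as in the limit of > 250000 nM in this assay, at which 2 of the 3 values shown sit. Among the compounds with values here, the single measured step, an at least 1.7-fold higher number from compound 1 to compound 2 (0.23 log units; that floor lies within the scatter), swaps tert-butyl for trifluoromethyl and leaves the aminophenyl untouched, so it does not bear on the step to compound 4 `Cc1ccc(CN2C(=O)S/C(=C\c3cccc(N)c3)C2=O)cc1`. The change here is 3-aminophenyl in place of 4-aminophenyl on a double-bonded chain carbon bound to a double-bonded ring carbon. Within the data shown here, compound 1 carries a 3-aminophenyl and a measured number, yet with tert-butyl rather than methyl, and no measured pair separates the two aminophenyls. Therefore no step beyond the scatter is expected, an at least 1.1-fold lower number from compound 3 to compound 4 (0.05 log units; that floor lies within the scatter), with a fair chance of another limit. Compound 4 is estimated at 220000 nM, ranging from 100000 nM to 450000 nM.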

Compound 4, half-maximal inhibitory concentration: 98000 nM
Compound 4: the middle estimate sits 2.2-fold (0.35 log units) above what was measured; measured number below the stated range.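

In this assay, the series now has a direct comparison of the two aminophenyls: an at least 2.5-fold lower number from compound 3 to compound 4 (0.40 log units; beyond the scatter). With 3-aminophenyl kept, methyl against trifluoromethyl gives an at least 2.5-fold lower number from compound 2 to compound 4 (0.40 log units; beyond the scatter), whereas methyl against tert-butyl gives a 1.5-fold lower number from compound 1 to compound 4 (0.17 log units; within the scatter), so those two groups are not separated. The steps from compound 2 and compound 3 start from a limit, so they give only a minimum size: the limit of > 250000 nM in this assay, at which 2 of the 4 values shown sit.

Going by these compounds, whether the 3-aminophenyl advantage holds with tert-butyl or trifluoromethyl remains open. So does the effect of a hydroxyl or carboxylic acid in place of the amine.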